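Lengthening the Phenoxy Linker of Compound 1

This account rests on a few compounds, and the source may have more. Where it says the series, first, only, none or still open, it means among the compounds named here.

Compound 1 `O=C(O)c1csc([C@H]2CC[C@@H]3[C@@H](/C=C/COc4ccccc4)[C@H](O)C[C@@H]3O2)n1` gives 3.8 nM in a functional assay on CHO cells for agonist activity at prostaglandin E2 receptor EP2 subtype (Homo sapiens), read by HTRF and cAMP accumulation, with a stated time of 30 min (a lower number here means that less compound is needed, a higher number that more compound is needed for the effect), the lowest of the three numbers at hand. Compound 2 `O=C(O)c1csc([C@H]2CC[C@@H]3[C@@H](COc4cccc(Cl)c4)[C@H](O)C[C@@H]3O2)n1` gives 6.5 nM, a number within the scatter of that of compound 1, while compound 3 `O=C(O)c1csc([C@H]2CC[C@@H]3[C@@H](CCCCCOc4ccccc4)[C@H](O)C[C@@H]3O2)n1` gives 28 nM, a number beyond the scatter and higher. Compound 4 `O=C(O)c1csc([C@H]2CC[C@@H]3[C@@H](/C=C/CCOc4ccccc4)[C@H](O)C[C@@H]3O2)n1` is not yet measured; it differs from compound 1 by phenoxymethyl in place of phenoxy on a saturated chain carbon bound to a double-bonded chain carbon. Among the compounds with values here, no step between measured compounds with this exact change is available, so the expectation rests on compound 3, whose longer saturated chain gives 28 nM. A modest rise in the number is expected, with a 2.4-fold higher number from compound 1 to compound 4 (0.37 log units; beyond the scatter) estimated as the step. Compound 4 is expected to give 9 nM, with a range from 3 nM to 30 nM.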

Compound 4, half-maximal effective concentration: 3.9 nM
The estimate for compound 4 lay 2.3-fold (0.36 log units) above the measured number, within the range that was stated.
By their numbers in this assay, from the lowest: compounds 1, 4 and 2 (each within the scatter of the next); then compound 3.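

In this assay the number stays within the scatter when phenoxymethyl takes the place of phenoxy on a saturated chain carbon bound to a double-bonded chain carbon (a 1.0-fold higher number from compound 1 to compound 4 (0.01 log units; within the scatter)). Within the data shown here, this is the first step that can be read at this position, and it shows that the double bond and the phenyl ether can stand with the added carbon and no change beyond the scatter. Nothing at hand gives a reason for this result.

Still open, as far as these compounds go, is whether 2-phenoxyethyl at this place would also hold the number. From the compounds shown here alone, an amine in place of the ether oxygen of compound 4 remains equally open.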